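Working notes: pyridin-4-yl in place of thiophen-3-yl

A few compounds are considered here, and "the series" means these few. Any claim that something is new, unique, unknown or untested is made for them only; others in the source may bear on it.

Values from a functional assay on MCF7 cells (Homo sapiens) for inhibition, read by sulforhodamine B assay, with a stated time of 72 h; a higher number here means a weaker inhibitor, a lower number a stronger inhibitor:
compound 1 `COc1ccc(C(=O)/C=C/c2cn(-c3ccccc3)nc2-c2ccsc2)c(OC)c1OC`: 7400 nM
compound 2 `COc1ccc(C(=O)/C=C/c2cn(-c3ccccc3)nc2-c2ccsc2)cc1OC`: 2800 nM
compound 3 `COc1ccc(C(=O)/C=C/c2cn(-c3ccccc3)nc2-c2ccsc2)c(OC)c1`: 9000 nM

Among the three numbers, compound 1 stands second highest. Its nearest neighbour is compound 3, with a 1.2-fold higher number from compound 1 to compound 3 (0.09 log units; within the scatter); its furthest is compound 2, with a 2.6-fold lower number from compound 1 to compound 2 (0.42 log units; beyond the scatter). The third measured step, a 3.2-fold higher number from compound 2 to compound 3 (0.51 log units; beyond the scatter), likewise moves only the methoxy pattern on the aryl group attached to the carbonyl. Every step seen so far therefore concerns that side of the shared core and leaves the group on the five-membered ring untouched.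

Compound 4 `COc1ccc(C(=O)/C=C/c2cn(-c3ccccc3)nc2-c2ccncc2)c(OC)c1OC` differs from compound 1 by pyridin-4-yl in place of thiophen-3-yl on an aromatic carbon. Among the measured compounds shown here, none of the measured steps bears on this change, so there is no basis in these numbers for a step beyond the scatter in either direction, and the uncertainty is wide. The estimate for compound 4 is 7500 nM (range 2500 nM to 25000 nM), which is expected to mean a 1.0-fold higher number from compound 1 to compound 4 (0.01 log units; within the scatter).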

Compound 4, half-maximal inhibitory concentration: 3300 nM
The estimate for compound 4 lay 2.3-fold (0.36 log units) above the measured number; the measured number falls inside the stated range.
By their numbers in this assay, from the lowest: compounds 2 and 4 (each within the scatter of the next); then compounds 1 and 3 (each within the scatter of the next).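

In this assay the group on the five-membered aromatic ring proves to be a position that can move the number: pyridin-4-yl in place of thiophen-3-yl gives a 2.2-fold lower number from compound 1 to compound 4 (0.35 log units; beyond the scatter) and so counts as a modest step. Among the compounds shown here, until now, every step concerned the methoxy pattern on the aryl group attached to the carbonyl, so this is the first sign that the opposite side of the shared core also matters, with the trimethoxy pattern of compound 1 held constant. Nothing available accounts for the step.

Open, from the compounds shown here alone, is whether plain phenyl, pyridin-3-yl or an aminophenyl group at this aromatic carbon would give a similar step, or whether it is particular to pyridin-4-yl. Also open, going by these compounds, is whether the same exchange would give a step of similar size with the 3,4-dimethoxyphenyl group of compound 2 on the carbonyl carbon.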